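This account rests on a few compounds, and the source may have more. Where it says the series, first, only, none or still open, it means among the compounds named here.

Measured in a functional assay on Hs-578T cells (Homo sapiens) for antiproliferative activity; on this read-out higher numbers stand for weaker inhibition of growth and lower numbers for stronger inhibition of growth:
compound 1 (`COCCCCCCCCCCCCCCC/C=C1\CC(CO)(COC(=O)C(C)(C)C)OC1=O`) gives 5.45 ug/mL
compound 2 (`COCCCCCCCCCCC/C=C1\CC(CO)(COC(=O)C(C)(C)C)OC1=O`) gives 7.34 ug/mL
compound 3 (`CCCCCCCCC(O)CCCCCC/C=C1\CC(CO)(COC(=O)C(C)(C)C)OC1=O`) gives > 10 ug/mL (a limit of the assay, not a number)

For the measured compounds named here, compound 2 (7.34 ug/mL) has compound 1 as its only neighbour with a number. Compound 4 (`CC(C)(C)C(=O)OCC1(CO)C/C(=C\CCCCCCCCCCCCCCC=O)C(=O)O1`) differs from compound 2 by one change (3-formylpropyl in place of methoxy on a saturated chain carbon, ten or more bonds along the chain from a double-bonded chain carbon): 3-formylpropyl in place of methoxy on a saturated chain carbon, ten or more bonds along the chain from a double-bonded chain carbon. Going by the values given here, the one measured step at that place (a 1.3-fold higher number from compound 1 to compound 2 (0.13 log units; within the scatter)) stayed within the scatter. The steps to compound 3 (an at least 1.8-fold higher number from compound 1 to compound 3 (0.26 log units; that floor lies within the scatter) and an at least 1.3-fold higher number from compound 2 to compound 3 (0.13 log units; that floor lies within the scatter)) act elsewhere on the chain, and their floors rest on a limit (the limit of > 10 ug/mL in this assay, at which 1 of the 3 values shown sits). No step beyond the scatter is therefore expected (a 1.2-fold lower number from compound 2 to compound 4 (0.09 log units; within the scatter)). The estimate for compound 4 is 6 ug/mL with an expected range from 2.5 ug/mL to 10 ug/mL in this assay.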

Compound 4, concentration for 50% growth inhibition: > 10 ug/mL
Compound 4: no number, only a limit (the forecaster's own chance of this, stated with the estimate: 15%); middle value at least 1.6-fold (0.22 log units) from the limit.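

In this assay compound 4 gives > 10 ug/mL, which is a limit of the assay and not a number. With the formyl-ended chain on a saturated chain carbon, the read-out shows an at least 1.3-fold higher number from compound 2 to compound 4 (0.13 log units; that floor lies within the scatter) and an at least 1.8-fold higher number from compound 1 to compound 4 (0.26 log units; that floor lies within the scatter), so this place no longer gives only numbers. The step between compound 3 and compound 4 cannot be read, and a second compound now sits at the limit: the limit of > 10 ug/mL in this assay, at which 2 of the 4 values shown sit.

On these data alone, how far compound 4 lies past its limit stays open, and so does whether the change exceeds the scatter. As far as these compounds go, what a carboxylic acid or an amine would give at this place also remains open.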